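Replacing the sulfur-bearing side group with methylsulfonyl

A few compounds are considered here, and "the series" means these few. Any claim that something is new, unique, unknown or untested is made for them only; others in the source may bear on it.

In a functional assay on L1210 cells (Mus musculus) for inhibition (a higher number here means a weaker inhibitor, a lower number a stronger inhibitor), compound 1 `CCC[S+](=N)([O-])CCC(NC(=O)c1ccc(NCc2cnc3nc(N)nc(O)c3n2)cc1)C(=O)O` gives 300000 nM and compound 2 `CCCC[S+](=N)([O-])CCC(NC(=O)c1ccc(NCc2cnc3nc(N)nc(O)c3n2)cc1)C(=O)O` gives 270000 nM with the two values level within the scatter. Among the compounds with values here, compound 2 therefore stands together with compound 1 on the numbers so far.

Compound 3 `CS(=O)(=O)CCC(NC(=O)c1ccc(NCc2cnc3nc(N)nc(O)c3n2)cc1)C(=O)O` follows from compound 2 through the change a group of 4 heavy atoms (1 carbon, 2 oxygen, 1 sulfur; no ring) in place of a group of 7 heavy atoms (4 carbon, 1 nitrogen, 1 oxygen, 1 sulfur; no ring), on a saturated chain carbon, three bonds along the chain from an amide-type nitrogen and a carbonyl carbon in which methylsulfonyl enters on a saturated chain carbon, three bonds along the chain from an amide-type nitrogen and a carbonyl carbon. Within the data shown here, the only measured step is a 1.1-fold lower number from compound 1 to compound 2 (0.05 log units; within the scatter) and it bears only loosely on this replacement, since no measured compound carries methylsulfonyl. No step beyond the scatter is expected in this assay in either direction, although the uncertainty is wide. The expected step is a 1.1-fold lower number from compound 2 to compound 3 (0.03 log units; within the scatter) and it rests on that single comparison. The estimate for compound 3 is 250000 nM with an expected range from 90000 nM to 700000 nM in this assay.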

Compound 3, half-maximal inhibitory concentration: 390000 nM
The estimate for compound 3 lay 1.6-fold (0.19 log units) below the measured number, within the range that was stated.
By their numbers in this assay, from the lowest: compounds 2, 1 and 3 (each within the scatter of the next).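

At this saturated chain carbon, three bonds along the chain from an amide-type nitrogen and a carbonyl carbon, methylsulfonyl can take the place of either larger sulfur-bearing group with no step beyond the scatter in this assay (a 1.4-fold higher number from compound 2 to compound 3 (0.16 log units; within the scatter); a 1.3-fold higher number from compound 1 to compound 3 (0.11 log units; within the scatter)). The earlier pair changed only the chain length on the sulfur, whereas between compound 2 and compound 3 the whole group changes, from 7 heavy atoms to 4 and from 1 hydrogen-bond donor to 0, and the number still stays within the scatter. No evidence bearing on this result is available.

On these data alone, whether any group at this carbon can move the number beyond the scatter stays open, for example a carboxylic acid or an amine. As far as these compounds go, all three compounds also share the same core, so the effect of changes elsewhere in the molecule remains unknown.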